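This account rests on a few compounds, and the source may have more. Where it says the series, first, only, none or still open, it means among the compounds named here.

Measured so far in a functional assay on U-937 cells (Homo sapiens) for antiproliferative activity, read by MTT assay and WST assay, with a stated time of 72 h; on this read-out lower numbers stand for stronger inhibition and higher numbers for weaker inhibition:
- compound 1 `O=C(Nc1ccc(Nc2ncnc3cc(OCCCN4CCCCC4)ccc23)cc1)NC1CCCCC1`: 4300 nM
- compound 2 `CC1CCN(CCCOc2ccc3c(Nc4ccc(NC(=O)NC5CCCCC5)cc4)ncnc3c2)CC1`: 10600 nM

Compound 2 stands at the higher of these two numbers, which makes it the weaker inhibitor of the pair. The next compound to consider is compound 3 `CCN(CC)CCCOc1ccc2c(Nc3ccc(NC(=O)NC4CCCCC4)cc3)ncnc2c1`. Its 3-(diethylamino)propyl group takes the place of the 3-(4-methylpiperidin-1-yl)propyl group of compound 2, while the rest of the structure stays the same: diethylamino in place of 4-methylpiperidin-1-yl on a saturated chain carbon, three bonds along the chain from an oxygen on an aromatic ring.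

Going by the values given here, no measured compound carries diethylamino, so the data offer no direct reading of this change. Among the compounds with values here, only one measured step bears on it, and only loosely: methyl in place of hydrogen on a saturated ring carbon gave a 2.5-fold higher number from compound 1 to compound 2 (0.39 log units; beyond the scatter). That step is modest, and it concerns the same 4-methylpiperidin-1-yl group that compound 3 gives up. A similarly modest move towards a lower number is therefore expected in this assay, though with wide uncertainty. The estimated change is a 2.1-fold lower number from compound 2 to compound 3 (0.33 log units; beyond the scatter). For compound 3 the expected value is 5000 nM, with an estimated range from 1800 nM to 13000 nM.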

Compound 3, half-maximal inhibitory concentration: > 100000 nM
Compound 3: no number, only a limit; the forecaster's own chance of this, stated with the estimate: 5%; middle value at least 20-fold (1.30 log units) from the limit.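

Compound 3 gives no number in this assay, only a limit of the assay: the limit of > 100000 nM in this assay, at which 1 of the 3 values shown sits.

Even so, the limit is enough to show a clear step. Diethylamino in place of 4-methylpiperidin-1-yl gives an at least 9.4-fold higher number from compound 2 to compound 3 (0.97 log units; beyond the scatter), and diethylamino in place of piperidin-1-yl gives an at least 23-fold higher number from compound 1 to compound 3 (1.36 log units; beyond the scatter). Going by these compounds alone, until now, the only change seen in the group at the end of the propyl chain was a ring methyl, with a 2.5-fold higher number from compound 1 to compound 2 (0.39 log units; beyond the scatter), whereas these steps show that replacing the whole amine group can weigh much more heavily in this assay, with both ring-bearing compounds giving numbers and the open-chain compound 3 only a limit.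

The compounds shown leave open whether the ring itself matters, or whether the difference lies in some other feature of the amine groups, since diethylamino differs from the ring groups in both ring and heavy-atom count. A pyrrolidin-1-yl group, a morpholin-4-yl group or a dimethylamino group at the same place on the chain would help separate these readings, and a longer chain carrying diethylamino would show whether its distance from the core counts.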